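The compounds below may be only part of what the source reports. "The series", "measured", "known", "first", "only" and "open" are said of these compounds alone.

Measured compounds:
- compound 1 `CC1(C)[C@H]2CC[C@]1(C)N(Cc1cn(-c3cccc(C#N)c3)nn1)C(=O)C2`: 320 nM
- compound 2 `CC1(C)[C@H]2CC[C@]1(C)N(Cc1cn(-c3ccc(O)cc3)nn1)C(=O)C2`: 410 nM

In a functional assay on LoVo cells (Homo sapiens) for inhibition, read by MTT assay, with a stated time of 24 h (a higher number here means a weaker inhibitor, a lower number a stronger inhibitor), compound 2 gives 410 nM, which stands level with compound 1 once the usual scatter is allowed for. Compound 3 `CC1(C)[C@H]2CC[C@]1(C)N(Cc1cn(-c3ccccc3)nn1)C(=O)C2` has not yet been measured. It has hydrogen in place of hydroxy on an aromatic carbon, so 4-hydroxyphenyl becomes phenyl: hydrogen in place of hydroxy on an aromatic carbon. Among the measured compounds shown here, only one measured step bears on this change. It swaps 3-cyanophenyl for 4-hydroxyphenyl on the same aromatic nitrogen, and it is small: a 1.3-fold higher number from compound 1 to compound 2 (0.11 log units; within the scatter). For the measured compounds named here, this is thin evidence, since no measured pair isolates the hydroxy group itself. Even so, no shift beyond the scatter is expected in this assay, and the estimated change is a 1.0-fold lower number from compound 2 to compound 3 (0.01 log units; within the scatter). The expected value for compound 3 is 400 nM, with an estimated range from 170 nM to 950 nM.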

Compound 3, half-maximal inhibitory concentration: 50 nM
Compound 3: middle estimate off by 8.0-fold (0.90 log units), on the high side; the measured number lies below the stated range.
By their numbers in this assay, from the lowest: compound 3; then compounds 1 and 2 (each within the scatter of the next).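

Taking the hydroxy group off the ring has a large effect in this assay, giving an 8.2-fold lower number from compound 2 to compound 3 (0.91 log units; beyond the scatter). Replacing the cyano group with hydrogen points the same way, giving a 6.4-fold lower number from compound 1 to compound 3 (0.81 log units; beyond the scatter), so the plain phenyl compound is the strongest inhibitor of the three. The earlier step could not reveal this: compound 1 and compound 2 sit level with each other, and only the unsubstituted ring shows that both substituted rings give weaker numbers.

No measurement shown here accounts for this gain. As far as these compounds go, it remains open whether any group on this ring can match hydrogen, for example a methyl group, a fluorine atom, an amine or a carboxylic acid, and whether the answer depends on where that group sits on the ring.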